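Fluorobenzyl ethers: the step from compound 1 to compound 3

This account rests on a few compounds, and the source may have more. Where it says the series, first, only, none or still open, it means among the compounds named here.

Measured so far:
compound 1, `Cc1ccc(NC(=S)NC(=O)c2ccc(OCc3ccc(C(F)(F)F)cc3)cc2)cc1-c1nc2ccccc2[nH]1`: 17600 nM
compound 2, `Cc1ccc(NC(=S)NC(=O)c2ccc(OCc3ccccc3F)cc2)cc1-c1nc2ccccc2[nH]1`: 1870 nM

In a functional assay on HT-29 cells (Homo sapiens) for inhibition, read by MTT assay, with a stated time of 48 h (a lower number here means a stronger inhibitor, a higher number a weaker inhibitor), compound 1 gives 17600 nM, the highest of the two numbers in hand. Compound 2 gives 1870 nM. Within the data shown here, the single measured step, a 9.4-fold lower number from compound 1 to compound 2 (0.97 log units; beyond the scatter), exchanges the 4-(trifluoromethyl)phenyl for a 2-fluorophenyl and is beyond the scatter.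

Compound 3, `Cc1ccc(NC(=S)NC(=O)c2ccc(OCc3cccc(F)c3)cc2)cc1-c1nc2ccccc2[nH]1`, differs from compound 1 by 3-fluorophenyl in place of 4-(trifluoromethyl)phenyl on a saturated chain carbon bound to an oxygen on an aromatic ring. The step from compound 1 to compound 2 bears on this change directly: both remove the same 4-(trifluoromethyl)phenyl and put a fluorophenyl in its place, 2-fluorophenyl in compound 2 and 3-fluorophenyl in compound 3. Among the measured compounds shown here, no 3-fluorophenyl analogue has been measured, so the size of the step rests on that one comparison. The direction expected is a lower number, of a size comparable to, though perhaps short of, the step seen for compound 2 at 1870 nM.

The step from compound 1 to compound 3 is therefore estimated as a 4.4-fold lower number from compound 1 to compound 3 (0.64 log units; beyond the scatter). Compound 3 is expected at 4000 nM, within a range of 1500 nM to 12000 nM.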

Compound 3, half-maximal inhibitory concentration: 55300 nM
Compound 3: middle estimate off by 14-fold (1.14 log units), on the low side; the whole stated range lies below it.
By their numbers in this assay, from the lowest: compound 2; then compound 1; then compound 3.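

In this assay, exchanging 2-fluorophenyl for 3-fluorophenyl on a saturated chain carbon bound to an oxygen on an aromatic ring gives a 30-fold higher number from compound 2 to compound 3 (1.47 log units; beyond the scatter) and is the largest step in the series, so the two fluorophenyl groups are not interchangeable at this position. Replacing 4-(trifluoromethyl)phenyl with a fluorophenyl also has no single direction: compound 2 stands lower than compound 1, whereas the 3-fluorophenyl gives a 3.1-fold higher number from compound 1 to compound 3 (0.50 log units; beyond the scatter) and leaves compound 1 between the two fluorinated analogues. No measurement shown here accounts for these steps.

The compounds shown leave open how an unsubstituted phenyl on the same chain carbon would compare with compound 1, compound 2 and compound 3, and so whether the fluorine in compound 2 lowers the number or the fluorine in compound 3 raises it. They also leave open whether the low number of compound 2 is particular to fluorine or would persist with a chlorine or a methoxy group in its place.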